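Dropping an Aromatic Methyl from Compound 2

The compounds below may be only part of what the source reports. "The series", "measured", "known", "first", "only" and "open" are said of these compounds alone.

Compound 1, `CC(=O)c1ccc2c(c1O)[C@@H]1c3c(ccc4c(=O)c(C)c(C)oc34)OC[C@@H]1C(C)(C)O2`: in a functional assay on MCF7 cells (Homo sapiens) for cytotoxicity, read by MTT assay (a lower number here means a stronger inhibitor, a higher number a weaker inhibitor), compound 1 gives only a limit of the assay, > 100000 nM.
Compound 2, `Cc1oc2c3c(ccc2c(=O)c1C)OC[C@H]1[C@@H]3c2c(ccc(C(=O)Cc3ccccc3)c2O)OC1(C)C`: in this assay compound 2 gives only a limit of the assay, > 100000 nM.

Among the measured compounds shown here, compound 2 thus stands at the limit of the assay, not at a number, and the only other value shown, that of compound 1, is a limit as well. For the measured compounds named here, the one measured step, a step that the two limits leave unreadable from compound 1 to compound 2, cannot be read because both of its ends sit at the limit of > 100000 nM in this assay, at which 2 of the 2 values shown sit.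

Compound 3, `Cc1coc2c3c(ccc2c1=O)OC[C@H]1[C@@H]3c2c(ccc(C(=O)Cc3ccccc3)c2O)OC1(C)C`, remains to be measured. It differs from compound 2 by hydrogen in place of methyl on an aromatic carbon: a methyl leaves and a hydrogen enters, on an aromatic carbon of a six-membered aromatic ring with 1 oxygen, next to the ring oxygen. Going by the values given here, no measured step of readable size bears on this change; both measured compounds merely sit at the limit. Compound 3 is therefore expected to stay at the limit too, with the step that the limit leaves unreadable from compound 2 to compound 3 expected to be nothing beyond the scatter. Compound 3 is estimated at 150000 nM, within 50000 nM to 500000 nM.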

Compound 3, half-maximal inhibitory concentration: > 100000 nM
Compound 3 was reported as a limit (the forecaster's own chance of this, stated with the estimate: 85%); the middle value lies beyond the limit too.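

The step from compound 2 to compound 3 cannot be read in this assay, because both compounds give only a limit of the assay: the limit of > 100000 nM in this assay, at which 3 of the 3 values shown sit.

The compounds shown leave open how strong any of them is, and whether hydrogen in place of methyl on the aromatic carbon changes cytotoxicity at all.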